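A few compounds are considered here, and "the series" means these few. Any claim that something is new, unique, unknown or untested is made for them only; others in the source may bear on it.

In an assay on microsomes from brain for inhibition of Fatty-acid amide hydrolase 1 (Rattus norvegicus), read by fluorescence and HPLC, with a stated time of 60 min (on this read-out lower numbers stand for stronger inhibition and higher numbers for weaker inhibition), three compounds that share one core have been measured. Compound 1 `CCCCCCCCc1ccc(OCC(=O)Cn2nnc(-c3ccccc3Cl)n2)cc1` gives 32 nM, compound 2 `CCCCCCCCc1ccc(OCC(=O)Cn2nnc(-c3ccncc3)n2)cc1` gives 24 nM, and compound 3 `CCCCCCCCc1ccc(OCC(=O)Cn2nnc(C(=O)O)n2)cc1` gives 41 nM. Compound 3 shows the highest number of the three, yet every step toward it lies within the scatter: a 1.3-fold higher number from compound 1 to compound 3 (0.11 log units; within the scatter) and a 1.7-fold higher number from compound 2 to compound 3 (0.23 log units; within the scatter). Compound 4 `CCCCCCCCc1ccc(OCC(=O)Cn2nnc(CCC(=O)O)n2)cc1` is not yet measured; it differs from compound 3 by 2-carboxyethyl in place of carboxy on an aromatic carbon. The two steps that changed the group at this same position, from compound 1 and from compound 2 to compound 3, were both small, so the change to compound 4 is expected to bring no step beyond the scatter in this assay, with a 1.1-fold higher number from compound 3 to compound 4 (0.04 log units; within the scatter) as the expected step. Compound 4 is therefore estimated at 45 nM, with a range from 18 nM to 110 nM.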

Compound 4, half-maximal inhibitory concentration: 30 nM
Estimate against measurement, compound 4: 1.5-fold (0.18 log units) above; low and high end bracket the measured number.
By their numbers in this assay, from the lowest: compounds 2, 4, 1 and 3 (each within the scatter of the next).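

In this assay, 2-carboxyethyl in place of carboxy gives a 1.4-fold lower number from compound 3 to compound 4 (0.14 log units; within the scatter), so a two-carbon extension of the group at this position stays within the scatter. The same holds against the two ring-bearing groups, with a 1.3-fold higher number from compound 2 to compound 4 (0.10 log units; within the scatter) and a 1.1-fold lower number from compound 1 to compound 4 (0.03 log units; within the scatter), so open-chain and ring-bearing groups are not told apart here. No measured evidence is available to explain these small steps. Still open, from the compounds shown here alone, is whether a longer chain ending in carboxy, or an amine on the same aromatic carbon, would also stay within the scatter.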